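Cyclobutyl in place of pyridin-2-yl on the amide carbonyl

The source may report more compounds than this note shows. Statements on the series, on what has been measured and on what is new or still open speak of the compounds shown alone.

Measured compounds:
compound 1 `CCCC(=O)N1CCC(NS(=O)(=O)c2ccc(NC(=O)c3ccc(CC)cc3)c3ccccc23)CC1` — 10.8 nM
compound 2 `CCCC(=O)N1CCC(NS(=O)(=O)c2ccc(NC(=O)c3nccn3C)c3ccccc23)CC1` — 20.4 nM
compound 3 `CCCC(=O)N1CCC(NS(=O)(=O)c2ccc(NC(=O)c3ccccn3)c3ccccc23)CC1` — 41.7 nM

In an in vitro functional assay on CHO/Galpha16 cells for antagonist activity at C-C chemokine receptor type 8 (Homo sapiens), read by FLIPR (on this read-out higher numbers stand for weaker inhibition and lower numbers for stronger inhibition), compound 3 stands at the highest number of the three: a 2.0-fold higher number from compound 2 to compound 3 (0.31 log units; beyond the scatter), and a 3.9-fold higher number from compound 1 to compound 3 (0.59 log units; beyond the scatter). Compound 1 and compound 2 lie within the scatter of each other, as a 1.9-fold higher number from compound 1 to compound 2 (0.28 log units; within the scatter) shows.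

Compound 4 `CCCC(=O)N1CCC(NS(=O)(=O)c2ccc(NC(=O)C3CCC3)c3ccccc23)CC1` differs from compound 3 in one place: cyclobutyl in place of pyridin-2-yl on a carbonyl carbon. Among the measured compounds shown here, none of the measured steps touches a non-aromatic ring on this carbonyl carbon; the three steps all trade one aromatic ring for another, and the largest of them, clearly beyond the scatter, is the change from 4-ethylphenyl: a 3.9-fold higher number from compound 1 to compound 3 (0.59 log units; beyond the scatter). For the measured compounds named here, there is therefore no directly comparable step, and the expectation rests only on the range those three compounds span.

Compound 4 is expected to give about 50 nM, with a range from 15 nM to 200 nM; this estimate means a 1.2-fold higher number from compound 3 to compound 4 (0.08 log units; within the scatter), a step not expected to lie clearly beyond the scatter.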

Compound 4, half-maximal inhibitory concentration: 57.9 nM
The estimate for compound 4 lay 1.2-fold (0.06 log units) below the measured number; measured number inside the range.
By their numbers in this assay, from the lowest: compounds 1 and 2 (each within the scatter of the next); then compounds 3 and 4 (each within the scatter of the next).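

In this assay, among the compounds shown here, compound 4 puts a non-aromatic ring on this carbonyl carbon for the first time, and the exchange of pyridin-2-yl for cyclobutyl stays within the scatter, with a 1.4-fold higher number from compound 3 to compound 4 (0.14 log units; within the scatter). Removing both the aromatic ring and its nitrogen therefore leaves the number level with that of compound 3, while the cyclobutyl compound stays clearly apart from the other two, with a 2.8-fold higher number from compound 2 to compound 4 (0.45 log units; beyond the scatter) and a 5.4-fold higher number from compound 1 to compound 4 (0.73 log units; beyond the scatter). Nothing measured here accounts for these numbers.

The compounds shown leave open how a plain phenyl would compare, and so whether the ethyl group of compound 1 matters to its lower number. They also leave open what an open chain such as n-butyl, or a saturated ring carrying an amine such as piperidin-4-yl, would give on this carbonyl carbon.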